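The source may hold more compounds than are shown below. What is called first, only, known or untested is meant among the compounds shown, and "the series" means these compounds.

Working notes on the series. Within the data shown here, compound 1 `Cc1c(C(=O)Nc2ccc(Oc3ncnc4[nH]cc(-c5ccccc5)c34)c(F)c2)c(=O)c2cc(Cl)ccc2n1C` is the one member with a numerical result: in an assay on isolated protein for inhibition of tyrosine-protein kinase receptor UFO (Homo sapiens), read by FRET and Z'-LYTE, with a stated time of 1.5 h (on this read-out lower numbers stand for stronger inhibition and higher numbers for weaker inhibition), compound 1 gives 1890 nM, and it stands apart from the limit of > 10000 nM in this assay, at which 1 of the 2 values shown sits. Among the measured compounds shown here, compound 2 `CCc1ccc2c(c1)c(=O)c(C(=O)Nc1ccc(Oc3ccnc(Cl)c3)c(F)c1)c(C)n2C` differs from compound 1 in more than one place, so no single step joins the two. In this assay compound 2 gives > 10000 nM, which is a limit of the assay rather than a number. Compound 3 `COc1ccc2c(c1)c(=O)c(C(=O)Nc1ccc(Oc3ncnc4[nH]cc(-c5ccccc5)c34)c(F)c1)c(C)n2C` has not yet been measured. Relative to compound 1 its change is methoxy in place of chloro on an aromatic carbon. For the measured compounds named here, no measured pair differs in that one place, so the size of this step is unanchored; the working expectation is a step within the usual scatter, with a lean toward slight loss. Compound 3 is therefore expected to give 2500 nM, with a range from 800 nM to 8000 nM. That estimate corresponds to an expected step of a 1.3-fold higher number from compound 1 to compound 3 (0.12 log units; within the scatter).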

Compound 3, half-maximal inhibitory concentration: 99 nM
The estimate for compound 3 lay 25-fold (1.40 log units) above the measured number, outside the stated range (below it).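

In this assay, among these compounds, this aromatic carbon turns out to be far from indifferent: methoxy in place of chloro gives a 19-fold lower number from compound 1 to compound 3 (1.28 log units; beyond the scatter), the only single-place comparison available. The finding therefore holds for this one change on the shared core and cannot yet be extended to other groups or other positions. Nothing measured here accounts for the size of the step.

The compounds shown leave open whether hydroxy, ethoxy or a dimethylamino group on this carbon would read closer to methoxy or to chloro, and where the unsubstituted carbon would fall. Compound 2 gives > 10000 nM, which is a limit of the assay, and it differs from compound 1 in more than one place, so it does not settle this question.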